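A few compounds are considered here, and "the series" means these few. Any claim that something is new, unique, unknown or untested is made for them only; others in the source may bear on it.

Measured in a functional assay on L1210 cells (Mus musculus) for inhibition, read by MTT assay, with a stated time of 72 h; a lower number here means a stronger inhibitor, a higher number a weaker inhibitor:
- Compound 1 `COc1cc(NC(C)CCCNC(=O)Nc2cccc(Cl)c2)c2ncccc2c1` gives 17000 nM
- Compound 2 `COc1cc(NC(C)CCCNC(=O)NNC(=O)Nc2ccc(O)cc2)c2ncccc2c1` gives 95000 nM

Of these two, compound 2 has the higher number, at 95000 nM, and so is the weaker inhibitor. Compound 3 `COc1cc(NC(C)CCCNC(=O)Nc2ccc(O)cc2)c2ncccc2c1` is the next to be measured. It differs from compound 2 by 4-hydroxyphenyl in place of ((4-hydroxyphenyl)carbamoyl)amino on an amide-type nitrogen, with 4-hydroxyphenyl in place of ((4-hydroxyphenyl)carbamoyl)amino on an amide-type nitrogen.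

Going by the values given here, only one measured step bears on this change, a 5.6-fold higher number from compound 1 to compound 2 (0.75 log units; beyond the scatter), which introduced the same ((4-hydroxyphenyl)carbamoyl)amino group in place of 3-chlorophenyl. Removing that group should therefore lower the number, though probably by less than that step, as compound 3 keeps 4-hydroxyphenyl rather than 3-chlorophenyl. Among the compounds with values here, no measured pair separates those two groups.

The expected change is a 2.7-fold lower number from compound 2 to compound 3 (0.43 log units; beyond the scatter) in this assay. For compound 3 the estimate is 35000 nM, within an expected range of 12000 nM to 90000 nM.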

Compound 3, half-maximal inhibitory concentration: 21000 nM
For compound 3 the middle estimate is 1.7-fold (0.22 log units) above the measured one; low and high end bracket the measured number.
By their numbers in this assay, from the lowest: compounds 1 and 3 (each within the scatter of the next); then compound 2.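

On the amide-type nitrogen, 4-hydroxyphenyl in place of ((4-hydroxyphenyl)carbamoyl)amino gives a 4.5-fold lower number from compound 2 to compound 3 (0.66 log units; beyond the scatter) in this assay, so the high number of compound 2 goes with the longer ((4-hydroxyphenyl)carbamoyl)amino unit and not with the 4-hydroxyphenyl ring alone, which compound 3 still carries. The new pair also separates the two aryl groups on this nitrogen, and 4-hydroxyphenyl in place of 3-chlorophenyl gives a 1.2-fold higher number from compound 1 to compound 3 (0.09 log units; within the scatter), so this assay does not tell them apart. Nothing available explains why either step comes out as it does.

Two aryl groups are too few to show how far this tolerance extends on this nitrogen. From the compounds shown here alone, it remains open whether an unsubstituted phenyl, or a phenyl bearing a carboxylic acid or an amine, would give a number in the same range.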